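A few compounds are considered here, and "the series" means these few. Any claim that something is new, unique, unknown or untested is made for them only; others in the source may bear on it.

Measured so far in a functional assay on MCF7 cells (Homo sapiens) for inhibition, read by CCK-8 assay, with a stated time of 48 h; a lower number here means a stronger inhibitor of growth, a higher number a weaker inhibitor of growth:
compound 1 `Cc1ccccc1Nc1nc(Nc2cccnc2)ncc1Cl`: 56500 nM
compound 2 `Cc1ccccc1Nc1nc(NCc2ccccc2)ncc1Cl`: > 100000 nM (a limit, not a number)

Compound 2 has no numerical standing and gives only a limit: the limit of > 100000 nM in this assay, at which 1 of the 2 values shown sits.

The next change gives compound 3 `Cc1ccccc1Nc1nc(NCc2ccco2)ncc1Cl`, with furan-2-yl in place of phenyl on a saturated chain carbon bound to a nitrogen on an aromatic ring. Put another way, benzyl goes to (furan-2-yl)methyl.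

Among the compounds with values here, one measured step bears on this, and only loosely: an at least 1.7-fold higher number from compound 1 to compound 2 (0.24 log units; that floor lies within the scatter). Within the data shown here, it also exchanges the group on that nitrogen, but it gives only a floor, and no measured step covers a swap of this kind. No step beyond the scatter is therefore expected in this assay, and no direction can be set. Another limit would be no surprise. The nearest true number is compound 1 at 56500 nM, and the expectation stays near the top of the range of the read-out.

The expected step is an at least 1.1-fold lower number from compound 2 to compound 3 (0.04 log units; that floor lies within the scatter).

Compound 3 is estimated at 90000 nM, with an expected range of 40000 nM to 150000 nM.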

Compound 3, concentration for 50% growth inhibition: > 100000 nM
Compound 3: no number, only a limit (the forecaster's own chance of this, stated with the estimate: 55%); middle value at least 1.1-fold (0.04 log units) away from the limit.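

In this assay compound 3 gives > 100000 nM, which is a limit of the assay and not a number, so furan-2-yl in place of phenyl on a saturated chain carbon bound to a nitrogen on an aromatic ring leaves a step that cannot be read. Within the data shown here, the only readable comparison is with the pyridin-3-yl compound, an at least 1.7-fold higher number from compound 1 to compound 3 (0.24 log units; that floor lies within the scatter), and as a floor within the scatter it sets no firm size for this exchange. With a second group on the methylene now at the limit, the read-out gives no ranking of benzyl against (furan-2-yl)methyl, and the series gathers at its ceiling: the limit of > 100000 nM in this assay, at which 2 of the 3 values shown sit.

Among these compounds, compound 1 remains the only compound here with a true number, so what the group on this nitrogen contributes in this assay stays open. Whether a carboxylic acid, a 2-aminoethyl chain or a longer chain ending in phenyl would bring a compound off the limit is also unresolved.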